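The compounds below may be only part of what the source reports. "The series", "measured", "known", "first", "only" and "open" are said of these compounds alone.

Working notes on the series. In a functional assay on HEY cells (Homo sapiens) for cytotoxicity, read by MTT assay, with a stated time of 72 h (a higher number here means a weaker inhibitor, a lower number a stronger inhibitor), compound 2 `N[C@H]1CC[C@H](Nc2c(C(=O)NCc3ccccc3)nc(Br)c3cccnc23)CC1` gives 8000 nM, and compound 1 `N[C@H]1CC[C@H](Nc2c(C(=O)NCc3ccc(Cl)cc3Cl)nc(Br)c3cccnc23)CC1` gives 5000 nM. Within the data shown here, these are the only two measured values, and they lie within the scatter of each other, so compound 2 has a single neighbour and no clear rank.

The next structure is compound 3 `N[C@H]1CC[C@H](Nc2c(C(=O)Nc3ccccc3)nc(Br)c3cccnc23)CC1`. The change is phenyl in place of benzyl on an amide-type nitrogen, which can also be read as benzylamino to anilino.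

Among the measured compounds shown here, one measured step bears on this change, and only indirectly: a 1.6-fold higher number from compound 1 to compound 2 (0.20 log units; within the scatter). That step replaces 2,4-dichlorophenyl with phenyl on a saturated chain carbon and leaves the benzyl link to the amide-type nitrogen in place. For the measured compounds named here, no measured compound carries phenyl directly on that nitrogen, so the direction of the new step is open.

Going by the values given here, with only that small step from compound 1 as a guide, no step beyond the scatter is expected in this assay. The expected change is no change at the digits printed from compound 2 to compound 3 (within the scatter). For compound 3 the estimated value is 8000 nM, with an expected range of 3000 nM to 20000 nM.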

Compound 3, half-maximal inhibitory concentration: 1000 nM
Compound 3: middle estimate off by 8.0-fold (0.90 log units), on the high side; measured number below the stated range.
By their numbers in this assay, from the lowest: compound 3; then compounds 1 and 2 (each within the scatter of the next).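

In this assay, this position on the amide-type nitrogen proves sensitive to the link itself: phenyl in place of benzyl gives an 8.0-fold lower number from compound 2 to compound 3 (0.90 log units; beyond the scatter) and so moves the number beyond the scatter, which the earlier change on the ring, with the benzyl link kept, did not do at a 1.6-fold higher number from compound 1 to compound 2 (0.20 log units; within the scatter) in this assay. The change from the substituted benzyl reads the same way, with phenyl in place of 2,4-dichlorobenzyl giving a 5.0-fold lower number from compound 1 to compound 3 (0.70 log units; beyond the scatter) as a second step beyond the scatter. Compound 3 therefore holds the lowest number of the three, and both benzyl-type amides, which lie within the scatter of each other, stand apart from it on the same side.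

Still open, going by these compounds, is whether 2,4-dichlorophenyl carried directly on the amide-type nitrogen would follow compound 3, and how a cyclohexyl group or a longer chain such as 2-phenylethyl would read at this position. Nothing available here accounts for the step from benzyl to phenyl, and its origin remains unexplained.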